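Swapping methyl for methylsulfanyl on a nucleoside core

A few compounds are considered here, and "the series" means these few. Any claim that something is new, unique, unknown or untested is made for them only; others in the source may bear on it.

Compound 1, `C#Cc1cn([C@@H]2O[C@H](CO)[C@@H](O)[C@H]2O)c2ncnc(C)c12`, is the reference point. Within the data shown here, in an ADME assay on BJ cells (Homo sapiens), read by MTT assay, with a stated time of 72 h (a lower number here means a stronger inhibitor, a higher number a weaker inhibitor), compound 1 gives 50 nM, the lowest of the three numbers measured so far. The two measured partners carry a ring in place of the ethynyl group on the shared core. Compound 2, `Cc1ncnc2c1c(-c1cc3ccccc3o1)cn2[C@@H]1O[C@H](CO)[C@@H](O)[C@H]1O`, gives 93900 nM, and compound 3, `Cc1ncnc2c1c(-c1ccoc1)cn2[C@@H]1O[C@H](CO)[C@@H](O)[C@H]1O`, gives 89200 nM. Both steps away from compound 1 are large: a 1900-fold higher number from compound 1 to compound 2 (3.27 log units; beyond the scatter), and a 1800-fold higher number from compound 1 to compound 3 (3.25 log units; beyond the scatter). Between the two ring-bearing compounds the step is small: a 1.1-fold lower number from compound 2 to compound 3 (0.02 log units; within the scatter).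

Compound 4, `C#Cc1cn([C@@H]2O[C@H](CO)[C@@H](O)[C@H]2O)c2ncnc(SC)c12`, keeps the ethynyl group and instead alters the other substituent on the core: methylsulfanyl in place of methyl on an aromatic carbon. Among the measured compounds shown here, none of the measured steps touches this position; all of them change the ethynyl group, so they say nothing direct about the methyl-to-methylsulfanyl replacement. For the measured compounds named here, with no step that bears on it, the expectation rests on the small size of the change, and a step in this assay within the scatter, or only slightly beyond it in either direction, is expected. The step expected is a 1.6-fold higher number from compound 1 to compound 4 (0.20 log units; within the scatter). Compound 4 is therefore estimated at 80 nM, with a range from 20 nM to 320 nM.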

Compound 4, half-maximal inhibitory concentration: 68600 nM
Compound 4: middle estimate off by 860-fold (2.93 log units), on the low side, outside the stated range (above it).
By their numbers in this assay, from the lowest: compound 1; then compounds 4, 3 and 2 (each within the scatter of the next).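

Replacing methyl with methylsulfanyl on the aromatic carbon opposite the ring nitrogen gives a 1400-fold higher number from compound 1 to compound 4 (3.14 log units; beyond the scatter) in this assay. Until now, only changes to the ethynyl group had produced large steps, but this result shows that the low number of compound 1 also depends on the methyl position, and that keeping the ethynyl group does not secure it: a change of one heavy atom for two, with one hydrogen-bond acceptor entering, is enough to produce a large step. Nothing available here explains why this small replacement has so large an effect.

The compounds shown carry only methyl and methylsulfanyl at this position, so they leave open whether the higher number goes with the sulfur atom, with the larger group, or with something else. Ethyl and methoxy would help separate these possibilities, while an amine or a single chlorine atom at the same place would show whether methyl is unusual there or whether other small groups can also keep the number low.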